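From Methyl to 4-Methylphenyl on a Sulfonyl Sulfur

This account rests on a few compounds, and the source may have more. Where it says the series, first, only, none or still open, it means among the compounds named here.

Measured in an ADME assay on HEp-2 cells (Homo sapiens) for cytotoxicity, read by MTT assay, with a stated time of 60 h; on this read-out higher numbers stand for lower toxicity in this test and lower numbers for higher toxicity in this test:
- compound 1 `Cc1ccc(S(=O)(=O)O[C@@H]2CO[C@H]3[C@@H]2OCc2nc4cc(Br)c(Br)cc4n23)cc1`: 87500 nM
- compound 2 `Cc1c(Br)cc2nc3n(c2c1Br)[C@H]1OC[C@@H](O)[C@H]1OC3`: 250000 nM
- compound 3 `Cc1c(Br)cc2c(nc3n2[C@H]2OC[C@@H](OS(C)(=O)=O)[C@H]2OC3)c1Br`: 15600 nM

Compound 3 stands lowest of the three measured compounds. Compound 1 is its nearest neighbour on the numbers and compound 2 the furthest, and both gaps lie beyond the usual scatter.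

Compound 4 `Cc1ccc(S(=O)(=O)O[C@@H]2CO[C@H]3[C@@H]2OCc2nc4c(Br)c(C)c(Br)cc4n23)cc1` has not yet been measured. It keeps the core of compound 3 and exchanges a single group: 4-methylphenyl in place of methyl on a sulfonyl sulfur. In words, this is 4-methylphenyl in place of methyl on a sulfonyl sulfur.

Going by the values given here, no two measured compounds differ in one place only, so the data offer no direct step for this exchange. The closest guide is compound 1, which also carries 4-methylphenyl on a sulfonyl sulfur but has a different core, and it reads 87500 nM. Among the compounds with values here, that value is higher than the one for compound 3, so a moderate upward step is expected in this assay, though the differing cores leave this uncertain. The expected size of the change is a 2.9-fold higher number from compound 3 to compound 4 (0.46 log units; beyond the scatter). The estimated value for compound 4 is 45000 nM, with an expected range from 15000 nM to 130000 nM.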

Compound 4, half-maximal cytotoxic concentration: 8940 nM
Beside the measured number, compound 4's estimate is 5.0-fold (0.70 log units) above it, and the stated range ends above it.
By their numbers in this assay, from the lowest: compounds 4 and 3 (each within the scatter of the next); then compound 1; then compound 2.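

In this assay, going by these compounds alone, the exchange of methyl for 4-methylphenyl on a sulfonyl sulfur gives a 1.7-fold lower number from compound 3 to compound 4 (0.24 log units; within the scatter) on an unchanged core, the first direct reading of this change that the compounds offer. A six-membered aromatic ring of carbon only enters at this place, yet the read-out does not separate the two groups, so on this core the test does not distinguish methylsulfonyl from (4-methylphenyl)sulfonyl. Nothing in the available data bears on the reason for this result.

Within the data shown here, this single pair covers only two groups on the sulfonyl sulfur, so it remains open whether an amine, a carboxylic acid or a longer alkyl chain at this place would also read within the scatter of compound 3. It also remains open whether the same exchange would give a similar step on the core of compound 1, which is shown here only with 4-methylphenyl on the sulfonyl sulfur.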